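Compound 2 and its 2,6-dichlorobenzyl counterpart

The compounds below may be only part of what the source reports. "The series", "measured", "known", "first", "only" and "open" are said of these compounds alone.

Going by the values given here, in a functional assay on I10 cells (Mus musculus) for inhibition, read by MTT assay, with a stated time of 72 h (a higher number here means a weaker inhibitor, a lower number a stronger inhibitor), compound 2 `C=CCc1ccc(OCc2ccc(Cl)cc2Cl)c(-c2ccc(O)c(CC=C)c2)c1` gives 21100 nM, the only actual number so far. Compound 1 `C=CCc1ccc(OCc2ccc(Cl)cc2Cl)c(-c2ccc(OCc3ccc(Cl)cc3Cl)c(CC=C)c2)c1` reads > 50000 nM, which is a limit of the assay. Compound 3 `C=CCc1ccc(OCc2ccc(Cl)c(Cl)c2)c(-c2ccc(OCc3ccc(Cl)c(Cl)c3)c(CC=C)c2)c1` reads > 50000 nM, also a limit. Among the compounds with values here, the one measured step, an at least 2.3-fold lower number from compound 1 to compound 2 (0.37 log units; beyond the scatter), puts hydrogen in place of 2,4-dichlorobenzyl on an oxygen on an aromatic ring. Compound 4 `C=CCc1ccc(OCc2c(Cl)cccc2Cl)c(-c2ccc(O)c(CC=C)c2)c1` differs from compound 2 as follows: 2,6-dichlorophenyl in place of 2,4-dichlorophenyl on a saturated chain carbon bound to an oxygen on an aromatic ring. That step is a different change, so it gives no size for this one. With compound 2 at 21100 nM as the anchor, no step beyond the scatter is expected in this assay. The expected step is a 1.1-fold lower number from compound 2 to compound 4 (0.02 log units; within the scatter). For compound 4 the estimated value is 20000 nM, with an expected range of 8000 nM to 45000 nM.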

Compound 4, half-maximal inhibitory concentration: 17200 nM
Compound 4: middle estimate off by 1.2-fold (0.07 log units), on the high side, within the range that was stated.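

In this assay, 2,6-dichlorophenyl in place of 2,4-dichlorophenyl gives a 1.2-fold lower number from compound 2 to compound 4 (0.09 log units; within the scatter), so this change in the chlorine pattern, unlike the earlier removal of a whole 2,4-dichlorobenzyl group, does not move the reading beyond the scatter. Comparisons with compound 1 and compound 3 cannot be read as sizes: the limit of > 50000 nM in this assay, at which 2 of the 4 values shown sit.

Open, on these data alone, is whether an unsubstituted benzyl, or a benzyl carrying an amine or a carboxylic acid, would read differently at this oxygen. Also open, as far as these compounds go, is how a compound with 2,6-dichlorobenzyl on both oxygens would read.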